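Hydroxy versus hydrogen on the aromatic ring of compound 1

A few compounds are considered here, and "the series" means these few. Any claim that something is new, unique, unknown or untested is made for them only; others in the source may bear on it.

Compound 1 `c1ccc2c(c1)CCCC2CCCN1CCN(C2CCCCC2)CC1` is the stronger of two measured compounds in an assay on membranes from brain (Cavia porcellus) for binding affinity to Sigma non-opioid intracellular receptor 1 (Homo sapiens) (on this read-out lower numbers stand for stronger inhibition and higher numbers for weaker inhibition), giving 0.61 nM. For the measured compounds named here, its methoxy analogue, compound 2 `COc1ccc2c(c1)C(CCCN1CCN(C3CCCCC3)CC1)CCC2`, gives 9.04 nM, and the single step of a 15-fold higher number from compound 1 to compound 2 (1.17 log units; beyond the scatter) is large. Compound 3 `Oc1ccc2c(c1)CCCC2CCCN1CCN(C2CCCCC2)CC1` carries hydroxy in place of hydrogen on an aromatic carbon. Going by the values given here, the only step that bears on this change is the one from compound 1 to compound 2, which weakened binding clearly; a smaller hydroxy group is expected to weaken it as well, though perhaps less. The expected step is a 4.1-fold higher number from compound 1 to compound 3 (0.61 log units; beyond the scatter), so compound 3 is estimated at 2.5 nM, within 0.7 nM to 9 nM.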

Compound 3, inhibition constant: 0.69 nM
Beside the measured number, compound 3's estimate is 3.6-fold (0.56 log units) above it; the measured number lies below the stated range.
By their numbers in this assay, from the lowest: compounds 1 and 3 (each within the scatter of the next); then compound 2.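

In this assay, adding a hydroxy group to the aromatic ring of compound 1 makes no difference beyond the usual scatter: a 1.1-fold higher number from compound 1 to compound 3 (0.05 log units; within the scatter). Until now, the only substituted ring was that of compound 2, which suggested that a ring substituent might cost binding. Compound 3 shows that this does not hold for every group, as this aromatic carbon can carry a hydroxy group while binding stays in the same range.

No available evidence explains this result. Going by these compounds, whether an amine or a fluorine atom on this same carbon would behave alike remains open.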